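Substitution on the sulfonamide nitrogen of compound 2

The source may hold more compounds than are shown below. What is called first, only, known or untested is meant among the compounds shown, and "the series" means these compounds.

In an ADME assay on NIH3T3 cells (Mus musculus) for cytotoxicity, read by MTT assay, with a stated time of 48 h (a lower number here means that less compound is tolerated, a higher number that more compound is tolerated), compound 1 (`COc1ccc(C(=O)/C=C/c2ccc(C)cc2)cc1S(N)(=O)=O`) gives 4300 nM, and compound 2 (`COc1ccc(/C=C/C(=O)c2ccc(OC)c(S(N)(=O)=O)c2)cc1`) gives 96000 nM, the higher of the two numbers. Compound 3 (`COc1ccc(/C=C/C(=O)c2ccc(OC)c(S(=O)(=O)Nc3c(N)nc(SC)[nH]c3=O)c2)cc1`) differs from compound 2 by a group of 10 heavy atoms (5 carbon, 3 nitrogen, 1 oxygen, 1 sulfur; one six-membered aromatic ring with 2 hetero atoms) in place of a hydrogen atom, on a sulfonamide nitrogen. Among the compounds with values here, the only measured step, a 22-fold higher number from compound 1 to compound 2 (1.35 log units; beyond the scatter), is large and beyond the scatter, but it concerns a methoxy in place of methyl on an aromatic carbon, so it shows only how far one change can move this series. A moderate fall in this assay is expected, with wide uncertainty, since compound 2 stands at 96000 nM. The estimated change is a 3.2-fold lower number from compound 2 to compound 3 (0.51 log units; beyond the scatter). The estimate for compound 3 is 30000 nM, with an expected range of 6000 nM to 150000 nM.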

Compound 3, concentration lethal to 50% of the cells: 6500 nM
Estimate against measurement, compound 3: 4.6-fold (0.66 log units) above, and the stated range covers the measured number.
By their numbers in this assay, from the lowest: compounds 1 and 3 (each within the scatter of the next); then compound 2.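

In this assay, the sulfonamide nitrogen is a second place where a single change moves the series by a large step: a 15-fold lower number from compound 2 to compound 3 (1.17 log units; beyond the scatter). Putting this ring-bearing group in place of the hydrogen atom means less compound is tolerated, the opposite direction to the change on the aromatic carbon, a 22-fold higher number from compound 1 to compound 2 (1.35 log units; beyond the scatter). Nothing available bears on the reason for this fall. As far as these compounds go, with only one substituent on this nitrogen, it remains open whether the full group is needed for the step, or whether a methyl or acetyl group there would lower the number similarly.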